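From a bromophenyl to a difluorophenyl: expecting little change

The source may report more compounds than this note shows. Statements on the series, on what has been measured and on what is new or still open speak of the compounds shown alone.

Measured in a functional assay on HCT-116 cells (Homo sapiens) for antiproliferative activity, read by WST assay, with a stated time of 72 h; a lower number here means a stronger inhibitor of growth, a higher number a weaker inhibitor of growth:
- compound 1 `N#Cc1ccc(CN[C@H]2[C@@H]3CN(c4ncc(C(=O)NO)cn4)C[C@@H]32)cc1` gives 270 nM
- compound 2 `O=C(NO)c1cnc(N2C[C@@H]3[C@H](C2)[C@H]3NCc2ccc(F)cc2)nc1` gives 380 nM
- compound 3 `O=C(NO)c1cnc(N2C[C@@H]3[C@H](C2)[C@H]3NCc2ccc(Br)cc2)nc1` gives 250 nM

Compound 3 stands level with the other two, since a 1.1-fold lower number from compound 1 to compound 3 (0.03 log units; within the scatter) and a 1.5-fold lower number from compound 2 to compound 3 (0.18 log units; within the scatter) are both small steps. The next compound, compound 4 `O=C(NO)c1cnc(N2C[C@@H]3[C@H](C2)[C@H]3NCc2cc(F)cc(F)c2)nc1`, keeps the shared core and differs from compound 3 in one place: 3,5-difluorophenyl in place of 4-bromophenyl on a saturated chain carbon bound to an amine nitrogen. In words, this is 3,5-difluorophenyl in place of 4-bromophenyl on a saturated chain carbon bound to an amine nitrogen.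

Going by the values given here, no measured compound carries 3,5-difluorophenyl, so the best guides are the single swaps on the aromatic ring. These are a 1.4-fold higher number from compound 1 to compound 2 (0.15 log units; within the scatter), a 1.1-fold lower number from compound 1 to compound 3 (0.03 log units; within the scatter) and a 1.5-fold lower number from compound 2 to compound 3 (0.18 log units; within the scatter). All three lie within the scatter, so no step beyond the scatter is expected in this assay. The estimate means a 1.3-fold higher number from compound 3 to compound 4 (0.12 log units; within the scatter), an expected step that stays within the scatter. Compound 4 is estimated at 330 nM, with an expected range of 160 nM to 650 nM.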

Compound 4, concentration for 50% growth inhibition: 200 nM
Beside the measured number, compound 4's estimate is 1.7-fold (0.22 log units) above it; low and high end bracket the measured number.
By their numbers in this assay, from the lowest: compounds 4, 3, 1 and 2 (each within the scatter of the next).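

Read in this assay the change to 3,5-difluorophenyl stays within the scatter against each earlier ring: against 4-bromophenyl (a 1.3-fold lower number from compound 3 to compound 4 (0.10 log units; within the scatter)), against 4-fluorophenyl (a 1.9-fold lower number from compound 2 to compound 4 (0.28 log units; within the scatter)) and against 4-cyanophenyl (a 1.4-fold lower number from compound 1 to compound 4 (0.13 log units; within the scatter)). Going by these compounds alone, the earlier compounds each carried one group on the ring, so this is the first sign that a ring with two fluorines can sit at this place, on a saturated chain carbon bound to an amine nitrogen, without a step beyond the scatter. All four compounds therefore remain level, and no order can be drawn among them.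

As far as these compounds go, whether a ring carrying a carboxylic acid or an amine, or a longer chain, would move the number beyond the scatter stays open. Nothing available here explains why these numbers stay so close.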